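Nitrophenyl for dichlorophenyl, tried on a second core

A few compounds are considered here, and "the series" means these few. Any claim that something is new, unique, unknown or untested is made for them only; others in the source may bear on it.

Compound 1 `COc1cc(/C=C2\CN(C)C/C(=C\c3ccc(Cl)c(Cl)c3)C2=O)cc(OC)c1` and compound 2 `COc1cc(/C=C2\CN(C)C/C(=C\c3cccc([N+](=O)[O-])c3)C2=O)cc(OC)c1` share one core; compound 3 `COc1cc(/C=C2\CN(C)C/C(=C\c3ccc(Cl)c(Cl)c3)C2=O)cc(OC)c1OC` and compound 4 `COc1cc(/C=C2\CN(C)C/C(=C\c3cccc([N+](=O)[O-])c3)C2=O)cc(OC)c1OC` share another. The two cores differ by methoxy in place of hydrogen on an aromatic carbon. In a functional assay on HeLa cells (Homo sapiens) for cytotoxicity, read by MTT assay, with a stated time of 24 h (a lower number here means a stronger inhibitor, a higher number a weaker inhibitor), compound 1 gives 6900 nM, compound 2 gives 2560 nM, and compound 3 gives 13500 nM. The change 3-nitrophenyl in place of 3,4-dichlorophenyl on a double-bonded chain carbon bound to a double-bonded ring carbon brought a 2.7-fold lower number from compound 1 to compound 2 (0.43 log units; beyond the scatter). The core change alone brought a 2.0-fold higher number from compound 1 to compound 3 (0.29 log units; within the scatter). Compound 4 carries the change 3-nitrophenyl in place of 3,4-dichlorophenyl on a double-bonded chain carbon bound to a double-bonded ring carbon on the core of compound 3; the place is described in the same words for both pairs, so it is the same change, seen for the second time here. The step expected for compound 4 is a 2.7-fold lower number from compound 3 to compound 4 (0.43 log units; beyond the scatter), resting on the earlier step of a 2.7-fold lower number from compound 1 to compound 2 (0.43 log units; beyond the scatter). Compound 4 is therefore estimated at 5000 nM, expected between 2500 nM and 10000 nM.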

Compound 4, half-maximal inhibitory concentration: 5540 nM
For compound 4 the middle estimate is 1.1-fold (0.04 log units) below the measured one; the range from low to high includes it.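

In this assay, 3-nitrophenyl in place of 3,4-dichlorophenyl gave a 2.4-fold lower number from compound 3 to compound 4 (0.39 log units; beyond the scatter), and the step held on the second core: the same change on two cores in this assay, a 2.7-fold lower number (0.43 log units; beyond the scatter) from compound 1 to compound 2 and a 2.4-fold lower number (0.39 log units; beyond the scatter) from compound 3 to compound 4, 1.1-fold (0.04 log units) apart, within the scatter of two such steps The methoxy in place of hydrogen gave a 2.2-fold higher number from compound 2 to compound 4 (0.34 log units; beyond the scatter), and this step also held with the other aryl group in place: the same change on two cores in this assay, a 2.0-fold higher number (0.29 log units; within the scatter) from compound 1 to compound 3 and a 2.2-fold higher number (0.34 log units; beyond the scatter) from compound 2 to compound 4, 1.1-fold (0.04 log units) apart, within the scatter of two such steps The two changes therefore combine consistently across these four compounds, but this does not show that either step would carry to a core outside this set, nor does it explain why the steps agree.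

On these data alone, it remains open whether a phenyl ring bearing an amine or a carboxylic acid would follow the same step. As far as these compounds go, the size of these steps in any other assay also remains open.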